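Trading an alkyne for an ethyl on a nucleoside core

The source may hold more compounds than are shown below. What is called first, only, known or untested is meant among the compounds shown, and "the series" means these compounds.

Compound 1 `CCC#C[C@@]1(O)[C@@H](CO)O[C@@H](n2ccc(N)nc2=O)[C@@H]1O` is the only one of the three measured compounds with a numerical result: in a functional assay on L1210 cells (Mus musculus), read by MTT assay (a higher number here means a weaker inhibitor, a lower number a stronger inhibitor), compound 1 gives 129000 nM. Compound 2 `C#C[C@@]1(O)[C@H](O)[C@@H](CO)O[C@H]1n1ccc(N)nc1=O` gives > 350000 nM, which is a limit of this assay rather than a number. Compound 3 `C#CC[C@]1(O)[C@@H](CO)OC(n2ccc(N)nc2=O)[C@@H]1O` likewise gives > 350000 nM, again a limit. Two of the three values therefore sit at the limit of > 350000 nM in this assay, at which 2 of the 3 values shown sit, and compound 1 stands alone with a number, itself a weak one.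

Compound 4 `CC[C@@]1(O)[C@@H](CO)O[C@@H](n2ccc(N)nc2=O)[C@@H]1O` differs from compound 1 in one place: ethyl in place of but-1-yn-1-yl on a saturated ring carbon. The but-1-yn-1-yl group leaves and ethyl enters on the same saturated ring carbon. Among the compounds with values here, no measured pair shows this change, so the size of the step is open. Because compound 1 gives 129000 nM, itself a weak result, compound 4 is expected to remain weak. The step is estimated as a 1.6-fold higher number from compound 1 to compound 4 (0.19 log units; within the scatter), a small move toward weaker inhibition, possibly none beyond the scatter. Compound 4 is thus estimated at 200000 nM, with a range from 60000 nM to 600000 nM.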

Compound 4, half-maximal inhibitory concentration: 269000 nM
Compound 4: the middle estimate sits 1.3-fold (0.13 log units) below what was measured; low and high end bracket the measured number.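

In this assay, within the data shown here, the first measured change at this saturated ring carbon, ethyl in place of but-1-yn-1-yl, gives a 2.1-fold higher number from compound 1 to compound 4 (0.32 log units; beyond the scatter). The move is modest, and the triple bond is not needed for a numerical result, as compound 4 gives 269000 nM with ethyl at this position. Compound 2 and compound 3 have no number, only a limit of the assay, so the two numerical results remain weak compared with the only other reference point here: the limit of > 350000 nM in this assay, at which 2 of the 4 values shown sit.

This single step changes the chain length and removes the triple bond together, so it cannot tell the two effects apart. A saturated butyl chain would separate them, while a methyl group or an amine at the same carbon would show whether any other group gives a stronger result.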